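Removing a Methyl Group and Toxicity Toward Kidney Cells

The source may report more compounds than this note shows. Statements on the series, on what has been measured and on what is new or still open speak of the compounds shown alone.

Compound 1 `FC(F)(F)c1ccc(NCc2cn(-c3ccccc3)nc2-c2ccccc2)cc1`, compound 2 `Cc1ccc(-c2nn(-c3ccccc3)cc2CNc2ccc(C(F)(F)F)cc2)cc1` and compound 3 `Cc1ccc(NCc2cn(-c3ccccc3)nc2-c2ccc(Br)cc2)cc1` are close relatives; compound 4 `Brc1ccc(-c2nn(-c3ccccc3)cc2CNc2ccccc2)cc1` has not yet been tested. In an ADME assay on MDBK cells (Bos taurus) for cytotoxicity, read by MTT assay, with a stated time of 72 h (on this read-out lower numbers stand for higher toxicity in this test and higher numbers for lower toxicity in this test), compound 1 gives 34000 nM. For compound 2 the read-out is a limit of the assay, > 100000 nM, not a number. For compound 3 the read-out is likewise a limit, > 100000 nM. The change hydrogen in place of methyl on an aromatic carbon brought an at least 2.9-fold lower number from compound 2 to compound 1 (0.46 log units; beyond the scatter). How the core of compound 3 differs from the core of compound 2 is not broken down here. The same change, (hydrogen in place of methyl on an aromatic carbon), leads from compound 3 to compound 4. Because (the limit of > 100000 nM in this assay, at which 2 of the 3 values shown sit), the size of the earlier step is known only as a bound, so the coming step can be judged only roughly. Compound 4 is expected to show an at least 1.6-fold lower number from compound 3 to compound 4 (0.22 log units; that floor lies within the scatter), in line with the earlier step. Compound 4 is therefore estimated at 60000 nM, with a plausible span from 20000 nM to 150000 nM and a fair chance that this assay again reports only a limit.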

Compound 4, half-maximal cytotoxic concentration: > 100000 nM
Compound 4: only a limit was reported (the forecaster's own chance of this, stated with the estimate: 40%); middle value at least 1.6-fold (0.22 log units) away from the limit.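

Compound 3 and compound 4 both give only a limit in this assay, not a number, so the step between them cannot be read, because of this: the limit of > 100000 nM in this assay, at which 3 of the 4 values shown sit. The compounds shown leave open whether the change from 4-methylphenyl to phenyl alters the read-out at all in this pair.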